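The compounds below may be only part of what the source reports. "The series", "measured", "known", "first", "only" and "open" are said of these compounds alone.

Measured compounds:
Compound 1 `O=C(Nc1ccc(-c2cnc3cc(C4=CCN(C5COC5)CC4)ccn23)cc1)c1ccc([N+](=O)[O-])o1` — in a functional assay on MGC-803 cells (Homo sapiens) for antiproliferative activity, read by CCK-8 assay, with a stated time of 72 h (a higher number here means a weaker inhibitor, a lower number a stronger inhibitor), compound 1 gives 1100 nM.
Compound 2 `O=C(Nc1ccc(-c2cnc3cc(N4CCCC4)ccn23)cc1)c1ccc([N+](=O)[O-])o1` — in this assay compound 2 gives 1150 nM.

Both compounds share the same core, an amide-linked nitrofuran attached through a phenyl ring to a fused bicyclic system, and differ only in the group carried on an aromatic carbon of that fused system. Compound 1 stands at one of two numbers that cannot be told apart: the step of a 1.0-fold higher number from compound 1 to compound 2 (0.02 log units; within the scatter), in which a pyrrolidine ring replaces the larger oxetane-bearing tetrahydropyridine, changes essentially nothing.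

Compound 3 `O=C(Nc1ccc(-c2cnc3cc(N4CCC4)ccn23)cc1)c1ccc([N+](=O)[O-])o1` takes the same route one ring size further: a group of 4 heavy atoms (3 carbon, 1 nitrogen; one four-membered non-aromatic ring with 1 hetero atom) in place of a group of 10 heavy atoms (8 carbon, 1 nitrogen, 1 oxygen; one four-membered non-aromatic ring with 1 hetero atom, one six-membered non-aromatic ring with 1 hetero atom), on an aromatic carbon. For the measured compounds named here, the only measured step that bears on this change is the one from compound 1 to compound 2, and it lay within the scatter. A small saturated nitrogen ring at this position therefore appears to be tolerated about as well as the bulkier group of compound 1, and no step beyond the scatter is expected in this assay for compound 3 either, with a 1.1-fold higher number from compound 1 to compound 3 (0.04 log units; within the scatter) as the estimated shift.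

Compound 3 is expected to give about 1200 nM in this assay, with a plausible range from 500 nM to 3000 nM.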

Compound 3, half-maximal inhibitory concentration: > 5000 nM
Compound 3: no number, only a limit (the forecaster's own chance of this, stated with the estimate: 3%); middle value at least 4.1-fold (0.61 log units) from the limit.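

In this assay, compound 3 carries a limit of the assay and not a true number: the limit of > 5000 nM in this assay, at which 1 of the 3 values shown sits.

Even so, the steps to it can be read as minimum sizes: azetidin-1-yl in place of pyrrolidin-1-yl gives an at least 4.3-fold higher number from compound 2 to compound 3 (0.63 log units; beyond the scatter), and the same ring in place of the larger group with two non-aromatic rings gives an at least 4.5-fold higher number from compound 1 to compound 3 (0.65 log units; beyond the scatter). The earlier pair, with a 1.0-fold higher number from compound 1 to compound 2 (0.02 log units; within the scatter), made this aromatic carbon look indifferent to the group it carries, but the four-membered ring shows that it is not, since it stands apart from both the five-membered ring and the larger group.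

For the compounds shown here, the true size of the loss stays open, as does its cause, since a limit fixes only one side of the value and three compounds cannot show why azetidin-1-yl differs. A piperidine, a morpholine or an open-chain dimethylamino group on this same aromatic carbon would show whether the four-membered ring is a lone exception or whether the activity depends more broadly on which amine sits here.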